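Replacing a methoxy with a methyl in compound 3

The source may report more compounds than this note shows. Statements on the series, on what has been measured and on what is new or still open speak of the compounds shown alone.

In a functional assay on HCT-116 cells (Homo sapiens) for inhibition, read by CCK-8 assay, with a stated time of 48 h (a lower number here means a stronger inhibitor, a higher number a weaker inhibitor), compound 1 `COc1ccc(CN(C(=O)CSC(=S)N2CCN(C(=O)OC(C)(C)C)CC2)c2cc(OC)c(OC)c(OC)c2)cc1` gives 620 nM. Compound 2 `COc1ccc(CN(C(=O)CSC(=S)N2CCN(C(=O)OC(C)(C)C)CC2)c2cc(OC)c(OC)c(OC)c2)cc1OC` gives > 20000 nM, which is only a limit of the assay and not a number. Within the data shown here, the one measured step, an at least 32-fold higher number from compound 1 to compound 2 (1.50 log units; beyond the scatter), comes with an added methoxy and ends at the limit of > 20000 nM in this assay, at which 1 of the 2 values shown sits. Compound 3 `COc1ccc(CN(C(=O)CSC(=S)N2CCN(C(=O)OC(C)(C)C)CC2)c2cc(OC)c(OC)c(OC)c2)cc1C` changes 3,4-dimethoxybenzyl to 4-methoxy-3-methylbenzyl, methyl in place of methoxy on an aromatic carbon. With that methoxy gone but a methyl in its place, a large move to a lower number is expected, though probably only part of the way back. The estimated change is an at least 6.6-fold lower number from compound 2 to compound 3 (0.82 log units; beyond the scatter). For compound 3 the estimate is 3000 nM, with an expected range of 700 nM to 15000 nM.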

Compound 3, half-maximal inhibitory concentration: > 20000 nM
Compound 3 was reported as a limit; the forecaster's own chance of this, stated with the estimate: 25%; middle value at least 6.6-fold (0.82 log units) from the limit.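

In this assay compound 3 gives > 20000 nM, which is a limit of the assay and not a number. Putting a methyl in place of the hydrogen brings an at least 32-fold higher number from compound 1 to compound 3 (1.50 log units; beyond the scatter), so at this position the loss also comes with a group that has no oxygen. The step between compound 2 and compound 3 cannot be read because both stand at the same limit: the limit of > 20000 nM in this assay, at which 2 of the 3 values shown sit.

Going by these compounds, whether a fluorine or a hydroxyl group at this position would keep the activity of compound 1 stays open.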